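Piperazin-1-yl to methylamino on the shared core

The source may hold more compounds than are shown below. What is called first, only, known or untested is meant among the compounds shown, and "the series" means these compounds.

Compound 1 (`CS(=O)(=O)Oc1c(C(=O)NCc2ccc(F)cc2)nc(Br)c2cccnc12`) gives > 20000 nM
Compound 2 (`O=C(NCc1ccc(F)cc1)c1nc(Br)c2cccnc2c1N1CCNCC1`) gives > 10000 nM

In a functional assay on HCT-116 cells (Homo sapiens) for cytotoxicity, read by MTT assay, with a stated time of 72 h (a higher number here means a weaker inhibitor, a lower number a stronger inhibitor), compound 2 stands only at a limit (> 10000 nM). Compound 1 also stands only at a limit (> 20000 nM). For the measured compounds named here, the one measured step is a step that the two limits leave unreadable from compound 1 to compound 2 and offers no size to carry forward. Compound 3 (`CNc1c(C(=O)NCc2ccc(F)cc2)nc(Br)c2cccnc12`) brings methylamino in place of piperazin-1-yl on an aromatic carbon. With no readable size behind it, no step beyond the scatter is expected in this assay and no direction can be favoured. The expected step is small (a step that the limit leaves unreadable from compound 2 to compound 3). Compound 3 is estimated at 15000 nM with an expected range from 5000 nM to 40000 nM and may well return only a limit.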

Compound 3, half-maximal inhibitory concentration: > 20000 nM
Compound 3: a limit, no number (the forecaster's own chance of this, stated with the estimate: 70%); middle value at least 1.3-fold (0.12 log units) from the limit.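

In this assay, for the compounds shown here, compound 3 gives > 20000 nM, a limit, so no step among compound 1, compound 2 and compound 3 can be read. Going by these compounds, whether any group on this aromatic carbon gives a measurable value in this assay remains open.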